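The source may hold more compounds than are shown below. What is called first, only, known or untested is meant among the compounds shown, and "the series" means these compounds.

Working notes on the series. Of the compounds shown here, two of the shared core have been measured. Compound 1 `CN1CCN(CCCCCCn2c3c(c4ccccc42)C(=O)c2c[n+]([O-])c4ccccc4c2C3=O)CC1` carries a long chain ending in a basic ring on the core nitrogen; in a functional assay on HCT-116 cells (Homo sapiens) for cytotoxicity, read by MTT assay, with a stated time of 72 h (on this read-out lower numbers stand for stronger inhibition and higher numbers for weaker inhibition), compound 1 gives 2900 nM. Compound 2 `CC1(C)OCC(Cn2cc(Cn3c4c(c5ccccc53)C(=O)c3c[n+]([O-])c5ccccc5c3C4=O)nn2)O1` instead bears a triazole-linked (2,2-dimethyl-1,3-dioxolan-4-yl)methyl group; in this assay compound 2 gives 70 nM. Compound 2 therefore has the lowest number of the two, and the gap to compound 1 lies beyond the usual scatter, so compound 2 is the stronger of the pair on this read-out.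

Compound 3 `O=C1c2c[n+]([O-])c3ccccc3c2C(=O)c2c1c1ccccc1n2Cc1cn([C@@H]2O[C@H](CO)[C@@H](O)[C@H](O)[C@H]2O)nn1` is not yet measured. It differs from compound 2 in one place: 3,4,5-trihydroxy-6-(hydroxymethyl)oxan-2-yl in place of (2,2-dimethyl-1,3-dioxolan-4-yl)methyl on an aromatic nitrogen. For the measured compounds named here, no measured pair of this series shows a change of this kind, so the size of the step cannot be read from existing data. A moderate weakening is expected, on the order of the scatter or a little beyond it, with the expected step of a 2.1-fold higher number from compound 2 to compound 3 (0.33 log units; beyond the scatter) pointing toward a higher number. Compound 3 is estimated to give 150 nM, with a plausible range from 40 nM to 600 nM.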

Compound 3, half-maximal inhibitory concentration: 130 nM
Beside the measured number, compound 3's estimate is 1.2-fold (0.06 log units) above it, within the range that was stated.
By their numbers in this assay, from the lowest: compounds 2 and 3 (each within the scatter of the next); then compound 1.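

In this assay, for the compounds shown here, 3,4,5-trihydroxy-6-(hydroxymethyl)oxan-2-yl in place of (2,2-dimethyl-1,3-dioxolan-4-yl)methyl on an aromatic nitrogen gives a 1.9-fold higher number from compound 2 to compound 3 (0.27 log units; within the scatter), the first step that can be read at this position. The change is large in what can be counted: a five-membered non-aromatic ring with 0 hydrogen-bond donors leaves, and a six-membered non-aromatic ring with 4 hydrogen-bond donors and 5 defined stereocentres enters. Even so, the two compounds cannot be told apart on this read-out, so at this position, and for this pair alone, such a change in the counted features comes with no difference beyond the scatter. No measurement available for the series explains this result.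

One step cannot show whether this holds for the position in general. Going by these compounds, it remains open whether a primary amine or a carboxylic acid on a short chain at this nitrogen would read the same way, and whether the oxane ring would do so with its hydroxyl groups present as acetates.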